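The compounds below may be only part of what the source reports. "The series", "measured", "known", "first", "only" and "open" are said of these compounds alone.

In an ADME assay on microsomes from liver (Homo sapiens) for metabolic stability, read by LC-MS, using NADPH, with a stated time of 10 min, tested at 10 uM (a lower number here means that the compound disappears faster, a higher number that the compound lasts longer), three compounds from one series have been measured, all sharing a core that carries an amino group and a trifluoromethyl-substituted pyridine ether, and differing only in the ring attached to an aromatic nitrogen. Compound 3 `Nc1ncnc2c1c(Oc1cc(C(F)(F)F)ccn1)nn2[C@H]1CC[C@@H](CO)CC1` gives 1.6 h. Compound 2 `Nc1ncnc2c1c(Oc1cc(C(F)(F)F)ccn1)nn2C1CCC1` gives 1.02 h. The gap between them, a 1.6-fold higher number from compound 2 to compound 3 (0.20 log units; within the scatter), sits within the ordinary scatter of this assay, so the two are best read as alike. Compound 1 `CO[C@H]1CC[C@H](n2nc(Oc3cc(C(F)(F)F)ccn3)c3c(N)ncnc32)CC1` reports only a limit, > 2.41 h, rather than a number; one of the three values sits at this limit (the limit of > 2.41 h in this assay, at which 1 of the 3 values shown sits). Within the data shown here, the one step that clearly stands out is an at least 2.3-fold lower number from compound 1 to compound 2 (0.37 log units; beyond the scatter), where a smaller ring replaced the larger substituted one.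

Compound 4 `Nc1ncnc2c1c(Oc1cc(C(F)(F)F)ccn1)nn2C1CC1` takes this shrinking of the ring further: cyclopropyl in place of 4-(hydroxymethyl)cyclohexyl on an aromatic nitrogen. Among the measured compounds shown here, the only measured step that moves from a six-membered substituted ring to a small plain ring is an at least 2.3-fold lower number from compound 1 to compound 2 (0.37 log units; beyond the scatter), and that step was beyond the scatter; the step of a 1.6-fold higher number from compound 2 to compound 3 (0.20 log units; within the scatter) in the opposite direction was not. On this basis compound 4 is expected to give a somewhat lower number than compound 3, by an estimated 1.8-fold lower number from compound 3 to compound 4 (0.25 log units; within the scatter). The estimate for compound 4 in this assay is 0.9 h, with a range from 0.45 h to 1.8 h.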

Compound 4, half-life: > 2.41 h
Compound 4 gave a limit, no number; the forecaster's own chance of this, stated with the estimate: 5%; middle value at least 2.6-fold (0.42 log units) from the limit.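

In this assay, the ring on this aromatic nitrogen does not simply give a lower number as it gets smaller: cyclopropyl in place of cyclobutyl gives an at least 2.3-fold higher number from compound 2 to compound 4 (0.37 log units; beyond the scatter), a step beyond the scatter, although the three-membered ring is the smallest of the series. The comparison with the larger ring is less sharp, with an at least 1.5-fold higher number from compound 3 to compound 4 (0.17 log units; that floor lies within the scatter); that floor lies within the scatter, so this step alone shows no clear change, although the small plain ring clearly gives up nothing relative to the 4-(hydroxymethyl)cyclohexyl group. Compound 1 and compound 4 both stand at a limit, so the step between them cannot be read and neither can be placed above the other: the limit of > 2.41 h in this assay, at which 2 of the 4 values shown sit.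

Going by these compounds, how far the number for compound 4 lies past that limit stays unknown, so the size of the cyclopropyl gain over cyclobutyl is only a floor. The compounds shown also leave open how an open chain such as isopropyl, or a cyclohexyl ring carrying an amine or a carboxylic acid, would behave at this nitrogen.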